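Chain extension on the saturated arm of the shared core

The compounds below may be only part of what the source reports. "The series", "measured", "known", "first", "only" and "open" are said of these compounds alone.

Going by the values given here, compound 3 `CCCCCCCCCCc1nc(N(C)C)c(C)c(C)c1O` gives 89% in a functional assay on cells (Lymphocyte), read by a luciferase reporter and ATP content, with a stated time of 48 h, tested at 5 uM (a lower number here means a stronger effect, a higher number a weaker effect of the compound at the concentration tested), the second highest of the three numbers measured so far. Compound 1 `CCCCCCCCCCCCCCCCc1c(C)c(N(C)C)nc(C)c1O` gives 96% in this assay, which lies within the scatter of compound 3. Among the compounds with values here, compound 2 `Cc1c(N(C)C)nc(CCCCCCCCCCO)c(O)c1C` gives 50% in this assay, and the step of a number 39 percentage points higher from compound 2 to compound 3 (beyond the scatter) is the only measured step in the set; it lies beyond the scatter.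

Compound 4 `CCCCCCCCCCCCCCCCCCCc1nc(N(C)C)c(C)c(C)c1O` differs from compound 3 by nonyl in place of hydrogen on a saturated chain carbon, ten or more bonds along the chain from an aromatic carbon. Within the data shown here, no measured step alters the length of a saturated chain; the one known step, a number 39 percentage points higher from compound 2 to compound 3 (beyond the scatter), concerns a hydroxy and does not bear directly on this change. Compound 1, whose core also carries a long saturated chain, gives 96%, within the scatter of compound 3, so among these compounds chain length gives no sign of shifting the read-out. Compound 4 is therefore expected to give 90% in this assay, with a range from 75% to 100%. The expected step is a number 1 percentage points higher from compound 3 to compound 4 (within the scatter), estimated to stay within the scatter.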

Compound 4, a percentage reported as activity, at one concentration (the size of the read-out at that concentration, not a potency): 102%
Estimate against measurement, compound 4: 12 percentage points below; the whole stated range lies below it.
By their numbers in this assay, from the lowest: compound 2; then compounds 3, 1 and 4 (each within the scatter of the next, the first and the last beyond it).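

In this assay, going by these compounds alone, nonyl in place of hydrogen on a saturated chain carbon, ten or more bonds along the chain from an aromatic carbon, gives the first measured step in chain length, a number 13 percentage points higher from compound 3 to compound 4 (beyond the scatter), so added saturated carbon at this position does move the read-out, if only modestly. Set against the hydroxy at the same place, the same nonyl gives a much larger step, a number 52 percentage points higher from compound 2 to compound 4 (beyond the scatter), so among these compounds the hydroxy at the chain end counts for more than the added chain length. No measurement at hand bears on the reason for either step.

On these data alone, whether an amine or a carboxylic acid at the chain end would give a number like that of compound 2 50% remains open. Also open, as far as these compounds go, is whether a hydroxy at the end of a longer chain would keep that number.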